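Solubility notes: compound 1 to compound 3

This account rests on a few compounds, and the source may have more. Where it says the series, first, only, none or still open, it means among the compounds named here.

Going by the values given here, compound 1 `CCOC(=O)C1=C(C)N/C(=C/c2cc(C)n(-c3ccc(Cl)cc3)c2C)C1=O` is the only member with a numeric read-out: in a physicochemical assay for solubility, read by nephelometry, in phosphate buffer, measured as kinetic solubility, at pH 6.5 (a lower number here means a less soluble compound, a higher number a more soluble compound), compound 1 gives 1.6 ug/mL. Compound 2 `CCOC(=O)C1=C(C)N/C(=C/c2cc(C)n(-c3cccc(OC)c3)c2C)C1=O` reaches only a limit, giving < 1.6 ug/mL in this assay. Among the compounds with values here, the single measured step, a number no higher from compound 1 to compound 2 (the limit leaves the size open), is therefore of unreadable size, its end resting at the limit of < 1.6 ug/mL in this assay, at which 1 of the 2 values shown sits. Compound 3 `CCOC(=O)C1=C(C)N/C(=C/c2cc(C)n(-c3ccc(CN4CCCCC4)cc3)c2C)C1=O` differs from compound 1 by (piperidin-1-yl)methyl in place of chloro on an aromatic carbon, a change of another kind than the aryl swap, so the measured step does not bear on it. Compound 3 is estimated at 20 ug/mL, range 3 ug/mL to 100 ug/mL, an upward step a 13-fold higher number from compound 1 to compound 3 (1.10 log units; beyond the scatter) that is expected but only loosely anchored.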

Compound 3, solubility: 12.5 ug/mL
Beside the measured number, compound 3's estimate is 1.6-fold (0.20 log units) above it; low and high end bracket the measured number.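

Going by these compounds alone, on an aromatic carbon para to a large group, (piperidin-1-yl)methyl in place of chloro gives the first step of readable size in this assay: a 7.8-fold higher number from compound 1 to compound 3 (0.89 log units; beyond the scatter). Within the data shown here, the step to compound 2 cannot be read, and this remains the only sized change on the aromatic ring carried by the nitrogen. Nothing shown gives a cause for this rise.

Open, going by these compounds, is whether the step belongs to the piperidine ring or to any amine at this place, such as dimethylaminomethyl or morpholin-4-ylmethyl. Also open, on these data alone, is how a carboxylic acid on the same carbon would read in this assay.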